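Trifluoromethyl in place of methoxy on a cytotoxicity series

The source may report more compounds than this note shows. Statements on the series, on what has been measured and on what is new or still open speak of the compounds shown alone.

Compound 1, `O=C(/C=C\Nc1ccc(F)cc1)c1nc(-c2ccc(F)cc2)n2ccccc12`, gives a limit of > 30000 nM in a functional assay on B16-F10 cells (Mus musculus) for cytotoxicity, read by MTT assay, with a stated time of 48 h; on this read-out higher numbers stand for weaker inhibition and lower numbers for stronger inhibition.
Compound 2, `COc1ccc(N/C=C\C(=O)c2nc(-c3ccc(OC)cc3)n3ccccc23)cc1`, gives 2120 nM in this assay.
Compound 3, `COc1ccc(-c2nc(C(=O)/C=C\Nc3ccc(F)cc3)c3ccccn23)cc1`, gives a limit of > 30000 nM in this assay.

Among the measured compounds shown here, compound 2 thus stands as the only number among the three values; the other two are limits (the limit of > 30000 nM in this assay, at which 2 of the 3 values shown sit). Compound 4, `COc1ccc(N/C=C\C(=O)c2nc(-c3ccc(C(F)(F)F)cc3)n3ccccc23)cc1`, differs from compound 2 by trifluoromethyl in place of methoxy on an aromatic carbon. For the measured compounds named here, the one readable step, an at least 14-fold higher number from compound 2 to compound 3 (1.15 log units; beyond the scatter), concerns the other methoxy, which compound 4 retains, and a step that the two limits leave unreadable from compound 1 to compound 3. Going by the values given here, no measured step covers the change made here. A weakening is expected for compound 4, a 2.8-fold higher number from compound 2 to compound 4 (0.45 log units; beyond the scatter), with wide uncertainty. Compound 4 is estimated at 6000 nM, between 1500 nM and 30000 nM.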

Compound 4, half-maximal inhibitory concentration: > 30000 nM
Compound 4 gave a limit, no number (the forecaster's own chance of this, stated with the estimate: 30%); middle value at least 5.0-fold (0.69 log units) away from the limit.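

Trifluoromethyl in place of methoxy on the 4-methoxyphenyl group gives an at least 14-fold higher number from compound 2 to compound 4 (1.15 log units; beyond the scatter) in this assay, the first measured step at this position, and it shows that the number of compound 2 does not survive this change. Compound 2 thus remains the only compound with a number, while compound 4 joins the others at a limit: the limit of > 30000 nM in this assay, at which 3 of the 4 values shown sit.

How far compound 4 lies past that limit cannot be read, and the step between the two other limits cannot be read either. As far as these compounds go, whether a hydroxyl, an amine or a chlorine at this position would retain a measurable number stays open.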